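Swapping the aryl group on the triazole nitrogen

The compounds below may be only part of what the source reports. "The series", "measured", "known", "first", "only" and "open" are said of these compounds alone.

Of the compounds shown here, three sharing one core have been tested in a functional assay on PC-12 cells (Rattus norvegicus) for cytotoxicity, read by MTT assay, with stated times of 2 h and 24 h, tested at 1 uM; on this read-out lower numbers stand for a weaker effect and higher numbers for a stronger effect at the one concentration tested. Compound 1 `Cc1ccc(-n2nc(-c3ccc(C(F)(F)F)cc3O)nc2-c2ccccc2O)cc1` gives 71.5% and holds the highest of the three numbers, although its neighbours stand close: compound 3 `Oc1cc(C(F)(F)F)ccc1-c1nc(-c2ccccc2O)n(-c2ccc(Br)cc2)n1` gives 69.4%, and compound 2 `CC(C)(C)c1ccc(-n2nc(-c3ccc(C(F)(F)F)cc3O)nc2-c2ccccc2O)cc1` gives 67.3%. The step of a number 2.1 percentage points lower from compound 1 to compound 3 (within the scatter) and the step of a number 4.2 percentage points lower from compound 1 to compound 2 (within the scatter) both lie within the scatter, as does a number 2.1 percentage points higher from compound 2 to compound 3 (within the scatter), so the three numbers cannot be ordered with confidence.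

The next compound, compound 4 `Oc1cc(C(F)(F)F)ccc1-c1nc(-c2ccccc2O)n(-c2cc(F)cc(F)c2)n1`, differs from compound 1 in one place: 3,5-difluorophenyl in place of 4-methylphenyl on an aromatic nitrogen. The 4-methylphenyl group leaves, and a 3,5-difluorophenyl group enters on an aromatic nitrogen of the five-membered aromatic ring with 3 nitrogen, next to the ring atom that bears a 2-hydroxyphenyl group.

All three measured steps concern changes on this same aromatic ring at this same nitrogen, and none of them moved the read-out beyond the scatter. On that basis the change to compound 4 is expected to produce no step beyond the scatter in this assay, so the estimated step of a number 3.5 percentage points lower from compound 1 to compound 4 (within the scatter) is small. Compound 4 is therefore estimated at 68%, with a likely range from 56% to 80%.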

Compound 4, a percentage reported as activity, at one concentration (the size of the read-out at that concentration, not a potency): 75.5%
Beside the measured number, compound 4's estimate is 7.5 percentage points below it, and the stated range covers the measured number.
By their numbers in this assay, from the lowest: compounds 2, 3, 1 and 4 (each within the scatter of the next).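

In this assay, a 3,5-difluorophenyl group on the aromatic nitrogen carries fluorine at two ring positions, whereas the earlier groups each carry one substituent at the 4-position, yet this different pattern gives a number 4 percentage points higher from compound 1 to compound 4 (within the scatter) and a number 6.1 percentage points higher from compound 3 to compound 4 (within the scatter) along with a number 8.2 percentage points higher from compound 2 to compound 4 (within the scatter) as the largest step in the set. Methyl, tert-butyl, bromo and now two fluorine atoms have therefore all been placed on this phenyl ring, and no step between any two of the four compounds separates them beyond the usual scatter. Nothing here offers a measured explanation for why these changes leave the read-out so flat.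

As far as these compounds go, all four compounds keep a phenyl ring with no hydrogen-bond donors or acceptors on this nitrogen, so it remains open whether an amine or a carboxylic acid on that ring, or a cyclohexyl ring or a longer chain in its place, would produce a step beyond the scatter. Each number also comes from one concentration, so the set says nothing about how potency might differ among these compounds.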